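Two Amides, Two Cores, One Repeated Swap

This account rests on a few compounds, and the source may have more. Where it says the series, first, only, none or still open, it means among the compounds named here.

The study compares a small set of anilide ethers that share one bicyclic core and differ in two places: the acyl group on the amide nitrogen and the aryl group on the ring nitrogen. Compound 1 `CCC/C=C/C(=O)Nc1cccc(Oc2nc(Nc3ccn(C)n3)nc3c2CSCC3)c1` carries a pent-1-en-1-yl group on the carbonyl carbon. In a functional assay on A549 cells (Homo sapiens) for antiproliferative activity, read by MTT assay, with a stated time of 72 h (a higher number here means a weaker inhibitor, a lower number a stronger inhibitor), compound 1 gives 8190 nM. Compound 2 `CC(C)=CC(=O)Nc1cccc(Oc2nc(Nc3ccn(C)n3)nc3c2CSCC3)c1` differs from it by the change (2-methylprop-1-en-1-yl in place of pent-1-en-1-yl on a carbonyl carbon), and in this assay compound 2 gives 44200 nM; the step is a 5.4-fold higher number from compound 1 to compound 2 (0.73 log units; beyond the scatter). Compound 3 `CCC/C=C/C(=O)Nc1cccc(Oc2nc(Nc3ccc(OC)cc3)nc3c2CSCC3)c1` keeps the pent-1-en-1-yl amide of compound 1 but has a different core, the difference being (4-methoxyphenyl in place of 1-methyl-1H-pyrazol-3-yl on a nitrogen on an aromatic ring). In this assay compound 3 gives 11900 nM, so the step is a 1.5-fold higher number from compound 1 to compound 3 (0.16 log units; within the scatter), and the two cores behave alike here.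

Compound 4 `COc1ccc(Nc2nc3c(c(Oc4cccc(NC(=O)C=C(C)C)c4)n2)CSCC3)cc1` is not yet measured. It stands to compound 3 as compound 2 stands to compound 1, through the change (2-methylprop-1-en-1-yl in place of pent-1-en-1-yl on a carbonyl carbon), at a place described in the same words in both pairs, so the author treats it as the same change made on the other core. Among the compounds with values here, because the only measured instance of this change reads a 5.4-fold higher number from compound 1 to compound 2 (0.73 log units; beyond the scatter), and because the cores proved close in a 1.5-fold higher number from compound 1 to compound 3 (0.16 log units; within the scatter), a step of similar size is expected. For compound 4 the estimated step is a 4.9-fold higher number from compound 3 to compound 4 (0.69 log units; beyond the scatter). Compound 4 is therefore expected to give about 58000 nM in this assay, most likely between 20000 nM and 160000 nM.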

Compound 4, half-maximal inhibitory concentration: 26900 nM
For compound 4 the middle estimate is 2.2-fold (0.33 log units) above the measured one, and the stated range covers the measured number.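

In this assay the change from pent-1-en-1-yl to 2-methylprop-1-en-1-yl on the carbonyl carbon again raises the number on the second core, with a 2.3-fold higher number from compound 3 to compound 4 (0.35 log units; beyond the scatter), and the two instances do not differ by more than two such steps can scatter: the same change on two cores in this assay, a 5.4-fold higher number (0.73 log units; beyond the scatter) from compound 1 to compound 2 and a 2.3-fold higher number (0.35 log units; beyond the scatter) from compound 3 to compound 4, 2.4-fold (0.38 log units) apart, within the scatter of two such steps. The swap of 1-methyl-1H-pyrazol-3-yl for 4-methoxyphenyl, now read under the second amide, gives a 1.6-fold lower number from compound 2 to compound 4 (0.22 log units; within the scatter), so these two groups remain indistinguishable under either amide: the same change on two cores in this assay, a 1.5-fold higher number (0.16 log units; within the scatter) from compound 1 to compound 3 and a 1.6-fold lower number (0.22 log units; within the scatter) from compound 2 to compound 4, 2.4-fold (0.38 log units) apart, within the scatter of two such steps. Within these four compounds the amide change therefore carries from one core to the other in direction, and its two sizes cannot be told apart, but two pairs in one assay do not establish a fixed size for the step or show that it would hold on any further core.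

The compounds shown leave open how an acyl group with a longer chain, or one carrying an amine or a carboxylic acid, would read in this assay. They also leave open whether the amide change would keep its direction with a plain phenyl or a pyridinyl group on the ring nitrogen.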